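The compounds below may be only part of what the source reports. "The series", "measured", "known", "first", "only" and "open" are said of these compounds alone.

Four compounds share one core, a ring bearing a ketone with two arms, one carrying a pyridine and the other a phenyl ring with a trifluoromethyl group, and a sulfonyl-linked phenyl ring that carries either a fluoro or a chloro group. Compound 1 is `O=C1/C(=C/c2cccnc2)CN(S(=O)(=O)c2ccc(F)cc2)C/C1=C\c1ccccc1C(F)(F)F`, compound 2 is `O=C1/C(=C/c2cccnc2)CN(S(=O)(=O)c2ccc(Cl)cc2)C/C1=C\c1ccccc1C(F)(F)F`, compound 3 is `O=C1/C(=C/c2ccncc2)CN(S(=O)(=O)c2ccc(F)cc2)C/C1=C\c1ccccc1C(F)(F)F` and compound 4, not yet measured, is `O=C1/C(=C/c2ccncc2)CN(S(=O)(=O)c2ccc(Cl)cc2)C/C1=C\c1ccccc1C(F)(F)F`.

In an ADME assay on L02 cells (Homo sapiens) for cytotoxicity, read by MTT assay, with a stated time of 24 h (a lower number here means a stronger inhibitor, a higher number a weaker inhibitor), compound 1 gives 16100 nM. Compound 2 gives 11900 nM, and compound 3 gives 12900 nM.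

From compound 1 to compound 2 the change is chloro in place of fluoro on an aromatic carbon, and in this assay this made a 1.4-fold lower number from compound 1 to compound 2 (0.13 log units; within the scatter). Compound 3 differs from compound 1 in its core, the change being (pyridin-4-yl in place of pyridin-3-yl on a double-bonded chain carbon bound to a double-bonded ring carbon), and here the step was a 1.2-fold lower number from compound 1 to compound 3 (0.10 log units; within the scatter).

Compound 4 is reached from compound 3 by chloro in place of fluoro on an aromatic carbon. This is the same change as from compound 1 to compound 2, made at the same place, but on the core of compound 3 rather than compound 1. Since the earlier step from compound 1 to compound 2 was a 1.4-fold lower number from compound 1 to compound 2 (0.13 log units; within the scatter), a step of similar size is expected, a 1.4-fold lower number from compound 3 to compound 4 (0.13 log units; within the scatter), with most of the uncertainty coming from the scatter of the measurement itself. On that basis compound 4 is estimated at 9500 nM in this assay, expected to fall between 5000 nM and 18000 nM.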

Compound 4, half-maximal inhibitory concentration: 14900 nM
Estimate against measurement, compound 4: 1.6-fold (0.20 log units) below, and the stated range covers the measured number.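

In this assay, chloro in place of fluoro on the core of compound 3 gives a 1.2-fold higher number from compound 3 to compound 4 (0.06 log units; within the scatter), and this step agrees with the earlier one on the core of compound 1: the same change on two cores in this assay, a 1.4-fold lower number (0.13 log units; within the scatter) from compound 1 to compound 2 and a 1.2-fold higher number (0.06 log units; within the scatter) from compound 3 to compound 4, 1.6-fold (0.19 log units) apart, within the scatter of two such steps. Pyridin-4-yl in place of pyridin-3-yl, read on the chloro compounds, gives a 1.3-fold higher number from compound 2 to compound 4 (0.10 log units; within the scatter), and this step likewise agrees with its earlier counterpart: the same change on two cores in this assay, a 1.2-fold lower number (0.10 log units; within the scatter) from compound 1 to compound 3 and a 1.3-fold higher number (0.10 log units; within the scatter) from compound 2 to compound 4, 1.6-fold (0.19 log units) apart, within the scatter of two such steps. Neither change shows a detectable dependence on the core it is made on, but every step here is small enough to be measurement noise, so the data do not show that either change has a real effect, that such an effect carries from one core to another, or that the steps' differing directions mean anything.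

A larger change might stand clear of the scatter, such as a bromo or methoxy group in place of the fluoro or chloro group on the sulfonyl-linked phenyl ring, or a plain phenyl ring in place of the pyridine. Going by these compounds, whether a step of that kind would keep its size from one core to another remains open.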